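The source may report more compounds than this note shows. Statements on the series, on what has been measured and on what is new or still open speak of the compounds shown alone.

Compound 3 `Cc1cc(C(=O)N2CCCCc3ccccc32)ccc1CNC(=O)NCC(=O)OC(C)(C)C` gives the highest number of the three in a functional assay on HEK293 cells for agonist activity at Vasopressin V2 receptor (Homo sapiens), read by a luciferase reporter and cAMP accumulation (on this read-out lower numbers stand for an effect already at smaller amounts and higher numbers for an effect only at larger amounts of compound), at 120 nM; compound 2 `Cc1cc(C(=O)N2CCCCc3ccccc32)ccc1CNC(=O)Nc1ccccc1F` gives 30 nM and compound 1 `Cc1cc(C(=O)N2CCCCc3ccccc32)ccc1CNC(=O)Nc1c(F)cccc1F` gives 2.1 nM. Compound 4 `Cc1cc(C(=O)N2CCCCc3ccccc32)ccc1CNC(=O)N1CCC[C@H]1C(=O)O` differs from compound 3 in one place: 2-carboxypyrrolidin-1-yl in place of ((tert-butoxycarbonyl)methyl)amino on a carbonyl carbon. The steps that touch the same nitrogen were a 57-fold higher number from compound 1 to compound 3 (1.76 log units; beyond the scatter) and a 4.0-fold higher number from compound 2 to compound 3 (0.60 log units; beyond the scatter), so what stands on this urea nitrogen matters beyond the scatter. Neither step shows a ring closure or a free carboxylic acid, so the direction is open; since both steps away from the fluorophenyl groups raised the number, a further rise seems more likely than a fall, estimated as a 3.3-fold higher number from compound 3 to compound 4 (0.52 log units; beyond the scatter). Compound 4 is therefore expected near 400 nM, within 80 nM to 2000 nM.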

Compound 4, half-maximal effective concentration: 680 nM
Estimate against measurement, compound 4: 1.7-fold (0.23 log units) below, and the stated range covers the measured number.
By their numbers in this assay, from the lowest: compound 1; then compound 2; then compound 3; then compound 4.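

In this assay the change to 2-carboxypyrrolidin-1-yl on the carbonyl carbon gives a 5.7-fold higher number from compound 3 to compound 4 (0.75 log units; beyond the scatter) and shows that the number keeps rising with a ring-bearing carboxylic acid at this place. Measured against the groups with fluorophenyl, the same group gives a 23-fold higher number from compound 2 to compound 4 (1.36 log units; beyond the scatter) and a 320-fold higher number from compound 1 to compound 4 (2.51 log units; beyond the scatter) as the largest gap shown here. Nothing available accounts for this rise. From the compounds shown here alone, the ring and the free carboxylic acid enter together in compound 4, so their separate shares stay open. Also open, going by these compounds, is how the methyl ester of this group, or its opposite stereocentre, would read.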